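Removing the Indole Methyl in a Cytotoxicity Series

A few compounds are considered here, and "the series" means these few. Any claim that something is new, unique, unknown or untested is made for them only; others in the source may bear on it.

Compound 1, `COc1cc(C(C2=C(O)C(=O)c3ccccc3C2=O)c2c[nH]c3ccc(Br)cc23)cc(OC)c1OC`: 9710 nM
Compound 2, `Cc1[nH]c2ccccc2c1C(C1=C(O)C(=O)c2ccccc2C1=O)c1ccc(Cl)cc1`: 8030 nM
Compound 3, `Cc1[nH]c2ccccc2c1C(C1=C(O)C(=O)c2ccccc2C1=O)c1ccc([N+](=O)[O-])cc1`: 4570 nM

All three compounds were tested in a functional assay on HeLa cells (Homo sapiens) for cytotoxicity, read by MTT assay, with a stated time of 48 h; a lower number here means a stronger inhibitor, a higher number a weaker inhibitor. The number for compound 2 lies between those of compound 1 and compound 3, and both gaps are within the scatter, so the three cannot be told apart on these data. Among the measured compounds shown here, the only single-point comparison available is a 1.8-fold lower number from compound 2 to compound 3 (0.24 log units; within the scatter), a change at the far aromatic ring that did not move the number beyond the scatter.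

Compound 4, `O=C1C(O)=C(C(c2ccc(Cl)cc2)c2c[nH]c3ccccc23)C(=O)c2ccccc21`, has not yet been measured. It differs from compound 2 in one place: hydrogen in place of methyl on an aromatic carbon. For the measured compounds named here, no measured step touches this position. Compound 1 also lacks the methyl but differs from compound 2 in several other places as well, so the number of compound 1, 9710 nM, cannot be read as a test of this single change. With nothing pointing to a shift, compound 4 is expected to give about 8000 nM, somewhere between 3000 nM and 20000 nM. The expected step, a 1.0-fold lower number from compound 2 to compound 4 (0.00 log units; within the scatter), is estimated to stay within the scatter.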

Compound 4, half-maximal inhibitory concentration: 37000 nM
The estimate for compound 4 lay 4.6-fold (0.67 log units) below the measured number; the measured number lies above the stated range.
By their numbers in this assay, from the lowest: compounds 3, 2 and 1 (each within the scatter of the next, the first and the last beyond it); then compound 4.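

In this assay the change from 2-methyl-1H-indol-3-yl to 1H-indol-3-yl gives a 4.6-fold higher number from compound 2 to compound 4 (0.66 log units; beyond the scatter), making compound 4 a weaker inhibitor than compound 2. This is the only step shown that lies beyond the scatter, whereas the change at the far aromatic ring gives a 1.8-fold lower number from compound 2 to compound 3 (0.24 log units; within the scatter) and stays within it. The methyl on this aromatic carbon, next to the ring nitrogen, therefore makes a measurable difference in this pair, but nothing measured here indicates why the number rises.

The compounds shown leave open whether an ethyl group, a longer chain or an amine at this place would give a number lower or higher than that of compound 2. They also leave open whether removing the methyl from compound 3 would give a step of similar size.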